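Dropping a Methyl from a Weak Sulfonamide

The compounds below may be only part of what the source reports. "The series", "measured", "known", "first", "only" and "open" are said of these compounds alone.

Of the compounds shown here, two built on a shared core have been tested in a functional assay on SK-MEL-28 cells (Homo sapiens) for cytotoxicity, read by MTT assay; a higher number here means a weaker inhibitor, a lower number a stronger inhibitor. Compound 1 `O=S(=O)(NCCCNc1nccc(-c2c(-c3cccc(F)c3)nc3sccn23)n1)c1ccc(C(F)(F)F)cc1` gives 11700 nM in this assay. Compound 2 `Cc1ccc(S(=O)(=O)NCCNc2nccc(-c3c(-c4cccc(F)c4)nc4sccn34)n2)cc1` reaches only the limit of this assay, > 20000 nM, so its exact potency is not known and it stands at the boundary of the measured range (the limit of > 20000 nM in this assay, at which 1 of the 2 values shown sits). These two compounds differ in more than one place, so their values show only that both are weak.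

Compound 3 `O=S(=O)(NCCNc1nccc(-c2c(-c3cccc(F)c3)nc3sccn23)n1)c1ccccc1` is compound 2 with hydrogen in place of methyl on an aromatic carbon. For the measured compounds named here, removing one carbon from the outer ring is a small change, and no measured step shows how such a change plays out. The expected change is small, a step that the limit leaves unreadable from compound 2 to compound 3, likely within the usual scatter. Compound 3 is therefore estimated at 25000 nM, with a range from 9000 nM to 70000 nM, and with a fair chance that this assay again reports only a limit.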

Compound 3, half-maximal inhibitory concentration: 19000 nM
Compound 3: the middle estimate sits 1.3-fold (0.12 log units) above what was measured, within the range that was stated.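

In this assay, compound 3 gives a measured value of 19000 nM, so a series member with a plain phenyl group on the sulfonyl falls inside the range the assay can read. Compound 2 remains a limit of the assay at > 20000 nM. Replacing 4-methylphenyl with phenyl gives an at least 1.0-fold lower number from compound 2 to compound 3 (0.02 log units; that floor lies within the scatter), and the true size of this step cannot be read because one end of it is a limit: the limit of > 20000 nM in this assay, at which 1 of the 3 values shown sits.

The compounds shown leave open whether any group on this aromatic carbon can move the value beyond the usual scatter. An amine or a carboxylic acid at this place, para to the large group, would test that, and would show whether this part of the molecule affects the cytotoxicity read-out at all.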